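Sulfonamide series: switching the group on the sulfonamide nitrogen

The source may hold more compounds than are shown below. What is called first, only, known or untested is meant among the compounds shown, and "the series" means these compounds.

Measured so far:
compound 1 `O=C(Nc1ccc(S(=O)(=O)Nc2ccccc2)cc1)c1cc2ccccc2oc1=O` 7760 nM
compound 2 `O=C(Nc1ccc(S(=O)(=O)Nc2ccccc2)cc1)c1ccc(Br)cc1F` 479 nM
compound 3 `O=C(NS(=O)(=O)c1ccc(NC(=O)c2ccc(Cl)cc2Cl)cc1)c1ccccc1` > 100000 nM

In a functional assay on HEK293 cells for agonist activity at probable G-protein coupled receptor 27 (Homo sapiens), read by a luciferase reporter and beta-arrestin recruitment, with a stated time of 10 min (on this read-out higher numbers stand for an effect only at larger amounts of compound and lower numbers for an effect already at smaller amounts), compound 3 reaches only the upper limit of the assay, > 100000 nM, with no number behind it (the limit of > 100000 nM in this assay, at which 1 of the 3 values shown sits). Compound 4 `O=C(Nc1ccc(S(=O)(=O)Nc2ccc(Cl)cc2)cc1)c1ccc(Cl)cc1Cl` is not yet measured; it differs from compound 3 by 4-chlorophenyl in place of benzoyl on a sulfonamide nitrogen. Like compound 4, compound 1 and compound 2 carry a ring directly on the sulfonamide nitrogen; in this assay compound 1 gives 7760 nM and compound 2 gives 479 nM. On that basis compound 4 is expected to move well beyond the scatter towards smaller amounts, a step of an at least 200-fold lower number from compound 3 to compound 4 (2.30 log units; beyond the scatter). The estimate for compound 4 in this assay is 500 nM, within 80 nM to 5000 nM.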

Compound 4, half-maximal effective concentration: > 100000 nM
Compound 4 ended at the assay's limit; the forecaster's own chance of this, stated with the estimate: 15%; middle value at least 200-fold (2.30 log units) away from the limit.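

Compound 3 and compound 4 both sit at a limit in this assay, so no step between them can be read: the limit of > 100000 nM in this assay, at which 2 of the 4 values shown sit.

The compounds shown leave open which of the differences between compound 2 and compound 4 goes with the separation in their values.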